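The source may report more compounds than this note shows. Statements on the series, on what has been measured and on what is new or still open speak of the compounds shown alone.

Measured so far:
compound 1 `CCN1CCN(CC(=O)NC2(c3ccc(Cl)cc3)C(=O)Nc3cc(Cl)c(Cl)cc32)CC1` — 110 nM
compound 2 `CCN1CCN(CC(=O)NC2(c3ccc(Cl)c(Cl)c3)C(=O)Nc3cc(Cl)cc(Cl)c32)CC1` — 7 nM

In an in vitro functional assay on CHO-CREluc cells for antagonist activity at growth hormone secretagogue receptor type 1 (Homo sapiens), read by a luciferase reporter, with a stated time of 4 h (on this read-out lower numbers stand for stronger inhibition and higher numbers for weaker inhibition), compound 1 gives 110 nM, the higher of the two numbers in hand; compound 2 gives 7 nM, a gap beyond the scatter. Within the data shown here, the two differ in several places, so no single step is drawn between them.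

Compound 3 `CN1CCN(CC(=O)NC2(c3ccc(Cl)cc3)C(=O)Nc3cc(Cl)c(Cl)cc32)CC1` differs from compound 1 only by hydrogen in place of methyl on a saturated chain carbon bound to an amine nitrogen in a ring, ethyl to methyl on the piperazine. Nothing measured bears on this change, so no step beyond the scatter is expected either way. The step from compound 1 to compound 3 is expected to be a 1.1-fold higher number from compound 1 to compound 3 (0.04 log units; within the scatter). Compound 3 is estimated at 120 nM, within 50 nM to 300 nM.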

Compound 3, half-maximal inhibitory concentration: > 10000 nM
Compound 3 ended at the assay's limit (the forecaster's own chance of this, stated with the estimate: 3%); middle value at least 83-fold (1.92 log units) away from the limit.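

In this assay, the change from 4-ethylpiperazin-1-yl to 4-methylpiperazin-1-yl gives an at least 90-fold higher number from compound 1 to compound 3 (1.95 log units; beyond the scatter), so activity in this series depends strongly on this position, a saturated chain carbon bound to an amine nitrogen in a ring. Compound 2 and compound 1 differ in several places and gave no such single-place reading. Compound 3 stands at a limit of the assay, so the step has no upper bound: the limit of > 10000 nM in this assay, at which 1 of the 3 values shown sits.

On these data alone, whether a propyl or cyclopropyl group on that piperazine nitrogen restores activity remains open. Also open, as far as these compounds go, is whether the same ethyl to methyl change on the core of compound 2 gives a step of similar size.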